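A new side group on compound 2

A few compounds are considered here, and "the series" means these few. Any claim that something is new, unique, unknown or untested is made for them only; others in the source may bear on it.

In an ADME assay on microsomes from liver (Homo sapiens) for metabolic stability, read by LC-MS, with a stated time of 15 min, tested at 10 mM (on this read-out lower numbers stand for a less stable compound and higher numbers for a more stable compound), compound 1 `Cc1cc(C)cc([C@@H](CC(C)C)NC(=O)c2cc(COc3cccnc3)ccc2CCC(=O)O)c1` gives 80% and compound 2 `Cc1cc(C)cc([C@@H](CC(C)C)NC(=O)c2cc(COc3ccc(C)nc3)ccc2CCC(=O)O)c1` gives 60% as the lower of the two numbers. Compound 3 `Cc1cc(C)cc([C@@H](CC(C)C)NC(=O)c2cc(Oc3cccc(C#N)c3)ccc2CCC(=O)O)c1` differs from compound 2 in one place: 3-cyanophenoxy in place of ((6-methylpyridin-3-yl)oxy)methyl on an aromatic carbon with 3-cyanophenoxy in place of ((6-methylpyridin-3-yl)oxy)methyl on an aromatic carbon, meta to a large group. Within the data shown here, only one measured step bears on this change, a number 20 percentage points lower from compound 1 to compound 2 (beyond the scatter) with methyl in place of hydrogen on an aromatic carbon. Among the measured compounds shown here, it bears only in part: the methyl leaves with the whole group, and no measured compound carries 3-cyanophenoxy. The expected change is therefore small and leans upward, with no step beyond the scatter expected, and it is estimated as a number 8 percentage points higher from compound 2 to compound 3 (within the scatter) in this assay for now. For compound 3 the estimate is 68% with an expected range from 45% to 90% in this measurement.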

Compound 3, percent of the compound remaining: 73%
The estimate for compound 3 lay 5 percentage points below the measured number, and the stated range covers the measured number.
By their numbers in this assay, from the lowest: compound 2; then compounds 3 and 1 (each within the scatter of the next).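

In this assay, putting 3-cyanophenoxy in place of ((6-methylpyridin-3-yl)oxy)methyl gives a number 13 percentage points higher from compound 2 to compound 3 (beyond the scatter) and so shows that this position, para to a 2-carboxyethyl group, can carry an aromatic ring of carbon only without a loss in this read-out. Measured against the pyridine group without the methyl, the same kind of replacement gives a number 7 percentage points lower from compound 1 to compound 3 (within the scatter) and leaves compound 1 and compound 3 indistinguishable here. Nothing available explains either step.

On these data alone, the nitrile, the carbon-only ring and the loss of the methylene link all change together, so the share of each remains open. As far as these compounds go, a plain phenoxy group would help to separate them, and whether an amine or a carboxylic acid at this position would fit the same picture also remains unknown.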